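A few compounds are considered here, and "the series" means these few. Any claim that something is new, unique, unknown or untested is made for them only; others in the source may bear on it.

Measured so far in a physicochemical assay for solubility; on this read-out higher numbers stand for higher solubility and lower numbers for lower solubility:
- compound 1 `CNC(=O)c1cc(C(=O)NC2CC2)cn(Cc2ccc(OC)cc2)c1=O`: >= 143 ug/mL, a limit
- compound 2 `CNC(=O)c1cc(C(=O)NCCC2CCOCC2)cn(Cc2ccccc2)c1=O`: >= 127 ug/mL, a limit
- compound 3 `CNC(=O)c1cc(C(=O)NC2CC2)c(C)n(Cc2ccccc2)c1=O`: >= 126 ug/mL, a limit

None of these three read-outs is an exact number. Compound 1 stands at >= 143 ug/mL, which is a limit of the assay and not a number. Its place relative to compound 2 and compound 3 therefore cannot be ranked.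

The next compound is compound 4 `CNC(=O)c1cc(C(=O)NC2CC2)cn(Cc2cccc([C@@H](C)O)c2)c1=O`, which keeps the core of compound 1. The change is 3-(1-hydroxyethyl)phenyl in place of 4-methoxyphenyl on a saturated chain carbon bound to an aromatic nitrogen. In words, it is 3-(1-hydroxyethyl)phenyl in place of 4-methoxyphenyl on a saturated chain carbon bound to an aromatic nitrogen.

Within the data shown here, no measured pair isolates a single change, and none gives a size or direction for this one. In this assay, no step beyond the usual scatter is expected, and the reference point is compound 1 at its limit of >= 143 ug/mL. The expected change is an at least 1.0-fold lower number from compound 1 to compound 4 (0.00 log units; that floor lies within the scatter). A limit rather than a number is the likely report for compound 4. Compound 4 is estimated at 140 ug/mL, with an expected range of 85 ug/mL to 210 ug/mL.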

Compound 4, solubility: >= 131 ug/mL
Compound 4: a limit, no number; the forecaster's own chance of this, stated with the estimate: 75%; the middle value lies beyond the limit too.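

Compound 1 and compound 4 both stand as limits in this assay, not as numbers, and no step can be read between them. The compounds shown leave open how the exact read-outs of 3-(1-hydroxyethyl)phenyl and 4-methoxyphenyl compare on the shared core.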